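The compounds below may be only part of what the source reports. "The series", "measured", "known", "first", "only" and "open" are said of these compounds alone.

Among the compounds with values here, in a functional assay on A549 cells (Homo sapiens) for inhibition, read by CCK-8 assay, with a stated time of 72 h, tested at 2 uM (on this read-out lower numbers stand for less inhibition of growth and higher numbers for more inhibition of growth at the one concentration tested), compound 1 `Cc1cc(C)cc(SCc2ccc(/C=C/C(=O)Nc3ccccc3N)cc2)c1` gives 46.1% and compound 2 `Nc1ccccc1NC(=O)/C=C/c1ccc(CSc2cccc(F)c2)cc1` gives 50.7% and so stands level with compound 1 within the scatter, these being the only two numbers so far. Compound 3 `Nc1ccccc1NC(=O)/C=C/c1ccc(CSc2ccc(C(F)(F)F)cn2)cc1` carries 5-(trifluoromethyl)pyridin-2-yl in place of 3-fluorophenyl on a sulfur and is still to be measured. Within the data shown here, the one measured step that bears on this change is a number 4.6 percentage points higher from compound 1 to compound 2 (within the scatter) and it too exchanges the group on that sulfur, but only between rings of carbon. Resting on that small step, no shift beyond the scatter is expected in this assay in either direction, though the range stays wide, as no ring with a hetero atom has been measured. The estimated step is a number 2.7 percentage points lower from compound 2 to compound 3 (within the scatter) on these numbers. Compound 3 is estimated at 48% with 30% and 64% as the ends of the range.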

Compound 3, percent growth inhibition at one concentration: 51.7%
Compound 3: middle estimate off by 3.7 percentage points, on the low side; the range from low to high includes it.
By their numbers in this assay, from the lowest: compounds 1, 2 and 3 (each within the scatter of the next).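

In this assay the group on the sulfur now includes a ring with a hetero atom: 5-(trifluoromethyl)pyridin-2-yl in place of 3-fluorophenyl gives a number 1 percentage points higher from compound 2 to compound 3 (within the scatter) and in place of 3,5-dimethylphenyl gives a number 5.6 percentage points higher from compound 1 to compound 3 (within the scatter) as well. At this position, on a sulfur whose other neighbour is a saturated chain carbon, neither a ring nitrogen nor a group of 10 heavy atoms in place of 7 moves the number beyond the scatter, so compounds 1, 2 and 3 stand level. Nothing measured here bears on why these three stand level.

As far as these compounds go, all three groups on the sulfur are six-membered aromatic rings, so how an amine, a carboxylic acid or a longer alkyl chain there would read stays open. From the compounds shown here alone, with one concentration per compound, it also stays open whether this levelness holds at other concentrations.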